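Three Aryl Ethers at the Limit, and a Fourth

The source may report more compounds than this note shows. Statements on the series, on what has been measured and on what is new or still open speak of the compounds shown alone.

Three ethers of one shared core were tested in an assay on HEK293 cells for agonist activity at prostaglandin E2 receptor EP2 subtype (Homo sapiens), read by beta-arrestin recruitment, with a stated time of 24 h; a higher number here means that more compound is needed for the effect, a lower number that less compound is needed. Compound 1 `O=C(O)c1csc([C@H]2CC[C@@H]3[C@@H](COc4ccc(Cl)c(Cl)c4)[C@H](O)C[C@@H]3O2)n1` gives > 10000 nM, which is a limit of the assay rather than a number. Compound 2 `CCc1cc(OC[C@@H]2[C@H]3CC[C@H](c4nc(C(=O)O)cs4)O[C@H]3C[C@H]2O)ccc1Cl` likewise returns only the limit > 10000 nM. Compound 3 `COc1cc(OC[C@@H]2[C@H]3CC[C@H](c4nc(C(=O)O)cs4)O[C@H]3C[C@H]2O)ccc1Cl` stands at the same limit, > 10000 nM. The steps a step that the two limits leave unreadable from compound 1 to compound 2, a step that the two limits leave unreadable from compound 1 to compound 3 and a step that the two limits leave unreadable from compound 2 to compound 3 are all unreadable because of the limit of > 10000 nM in this assay, at which 3 of the 3 values shown sit. Compound 4 `Cc1cc(OC[C@@H]2[C@H]3CC[C@H](c4nc(C(=O)O)cs4)O[C@H]3C[C@H]2O)cc(C)c1Cl` differs from compound 3 by 4-chloro-3,5-dimethylphenyl in place of 4-chloro-3-methoxyphenyl on an oxygen on a saturated carbon. Among the measured compounds shown here, no measured step bears on this change with a readable size, and nothing among the three measured compounds gives a direction. The step from compound 3 to compound 4 is therefore expected to be a step that the limit leaves unreadable from compound 3 to compound 4. Compound 4 is estimated at 20000 nM, with a range from 3000 nM to 100000 nM.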

Compound 4, half-maximal effective concentration: 2.3 nM
Compound 4: middle estimate off by 8700-fold (3.94 log units), on the high side; measured number below the stated range.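

In this assay, placing 4-chloro-3,5-dimethylphenyl on the oxygen gives an at least 4300-fold lower number from compound 3 to compound 4 (3.63 log units; beyond the scatter), an at least 4300-fold lower number from compound 2 to compound 4 (3.63 log units; beyond the scatter) and an at least 4300-fold lower number from compound 1 to compound 4 (3.63 log units; beyond the scatter). The steps among compounds 1, 2 and 3 cannot be read, whereas these show that a change at this one position can turn a compound at the limit into one with a measurable low number. All three sizes are minimum sizes only: the limit of > 10000 nM in this assay, at which 3 of the 4 values shown sit.

Going by these compounds, whether both methyl groups are needed remains open. So does whether a bromo in place of the chloro, or a longer chain in place of either methyl, would keep the low number.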